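A few compounds are considered here, and "the series" means these few. Any claim that something is new, unique, unknown or untested is made for them only; others in the source may bear on it.

Of the compounds shown here, two that share one core have so far been tested in a functional assay on MIA PaCa-2 cells (Homo sapiens) for inhibition, read by MTT assay, with a stated time of 7 days; a lower number here means a stronger inhibitor, a higher number a weaker inhibitor. Compound 1 `CCN(CC)S(=O)(=O)c1ccc(S(=O)(=O)N2CCC[C@@H](C(=O)N[C@@H]3CCN(C(=O)OC(C)(C)C)C3)C2)cc1` gives in this assay 200 nM. Compound 2 `CCN(CC)C(=O)[C@@H]1CCCN(S(=O)(=O)c2ccc(S(=O)(=O)N(CC)CC)cc2)C1` gives in this assay 6400 nM, the higher of the two numbers and so the weaker inhibitor of the pair; its gap to compound 1 lies beyond the usual scatter. Among the compounds with values here, the two differ in what hangs from the carbonyl carbon, and no single-change step between them is available, so only their two values speak.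

Compound 3 `CCN(CC)S(=O)(=O)c1ccc(S(=O)(=O)N2CCC[C@@H](C(=O)NC3COC3)C2)cc1` has not yet been measured. It differs from compound 2 in one place: (oxetan-3-yl)amino in place of diethylamino on a carbonyl carbon. The group that enters brings a hydrogen-bond donor and a hydrogen-bond acceptor into a position where compound 2 has none, and compound 1, which also carries a nitrogen with a hydrogen at that carbonyl, sits at 200 nM. The step of a 4.3-fold lower number from compound 2 to compound 3 (0.63 log units; beyond the scatter) is expected to lower the number beyond the scatter, though not to the level of compound 1. Compound 3 is therefore estimated at 1500 nM, in a range from 400 nM to 6000 nM.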

Compound 3, half-maximal inhibitory concentration: 2300 nM
Beside the measured number, compound 3's estimate is 1.5-fold (0.19 log units) below it; low and high end bracket the measured number.
By their numbers in this assay, from the lowest: compound 1; then compound 3; then compound 2.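

In this assay, the change at this carbonyl carbon gives a 2.8-fold lower number from compound 2 to compound 3 (0.44 log units; beyond the scatter), so the position responds even when diethylamino gives way to a group with the same count of heavy atoms. Compound 1 and compound 3 both carry the amide hydrogen, yet oxetan-3-yl in place of 1-(tert-butoxycarbonyl)pyrrolidin-3-yl on that nitrogen gives a 12-fold higher number from compound 1 to compound 3 (1.06 log units; beyond the scatter), a larger step than the first, so the amide hydrogen alone does not bring the number down to that of compound 1. The data offer no measurement that explains either step.

Going by these compounds, the step to compound 3 brings in the amide hydrogen, the four-membered ring and the ring oxygen all at once, so what each contributes stays open; ethylamino would carry the hydrogen without a ring, and cyclobutylamino would carry a ring without the oxygen. On these data alone, it also stays open whether the lower number of compound 1 goes with its pyrrolidine ring or with its tert-butoxycarbonyl group, a question that a plain pyrrolidin-3-yl with a free amine on the same nitrogen would address.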